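Methyl added to an amine chain in a benzofuran series

The source may hold more compounds than are shown below. What is called first, only, known or untested is meant among the compounds shown, and "the series" means these compounds.

Measured compounds in a functional assay on U-937 cells (Homo sapiens) for antiproliferative activity, read by MTT assay, with a stated time of 24 h; on this read-out higher numbers stand for weaker inhibition and lower numbers for stronger inhibition:
compound 1, `CCCCc1oc2ccccc2c1C(=O)c1ccc(OCC(=O)NCc2ccccc2)cc1`, 16300 nM
compound 2, `CCCCc1oc2ccccc2c1C(=O)c1ccc(OCC(=O)N[C@@H](C)c2ccccc2)cc1`, 33800 nM
compound 3, `CCCCc1oc2ccccc2c1C(=O)c1cc(I)c(OCCCN2CCN(C)CC2)c(I)c1`, a limit only

Compound 1 and compound 2 share a core, and the step between them is methyl in place of hydrogen on a saturated chain carbon bound to an amide-type nitrogen and an aromatic carbon. In this assay it gives a 2.1-fold higher number from compound 1 to compound 2 (0.32 log units; beyond the scatter). For compound 3 the assay returns only > 50000 nM, which is a limit of the measurement and not a number. The difference between the core of compound 3 and the core of compound 1 is not broken down here.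

Compound 4, `CCCCc1oc2ccccc2c1C(=O)c1cc(I)c(OCCCN2CCN(CC)CC2)c(I)c1`, is not yet measured. Its relation to compound 3 is methyl in place of hydrogen on a saturated chain carbon bound to an amine nitrogen in a ring. This is the same kind of change as that from compound 1 to compound 2, though the place differs: there the carbon is bound to an amide-type nitrogen and an aromatic carbon, here to an amine nitrogen in a ring. The earlier step was modest, and compound 3 already sits at the limit of > 50000 nM in this assay, at which 1 of the 3 values shown sits, so compound 4 is expected to stay near that limit, with an estimated step that the limit leaves unreadable from compound 3 to compound 4. Compound 4 is estimated at 70000 nM.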

Compound 4, half-maximal inhibitory concentration: 13700 nM
Compound 4: the middle estimate sits 5.1-fold (0.71 log units) above what was measured, and the stated range ends above it.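

In this assay, the change from 4-methylpiperazin-1-yl to 4-ethylpiperazin-1-yl gives an at least 3.6-fold lower number from compound 3 to compound 4 (0.56 log units; beyond the scatter). The added methyl therefore does not carry over from one core to the other with the same result, since the two steps run in opposite directions: the same change on two cores in this assay, a 2.1-fold higher number (0.32 log units; beyond the scatter) from compound 1 to compound 2 and an at least 3.6-fold lower number (0.56 log units; beyond the scatter) from compound 3 to compound 4, at least 7.5-fold (0.87 log units) apart, beyond the scatter of two such steps These two pairs differ in the place of the methyl as well as in the core, so they do not show which of the two accounts for the gap.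

On these data alone, what a propyl group or a longer chain would give in place of the ethyl of 4-ethylpiperazin-1-yl stays open. So does the result of adding the methyl on a saturated chain carbon bound to an amide-type nitrogen and an aromatic carbon on the core of compound 3.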